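Trading one fluoro for hydrogen at the assay limit

The compounds below may be only part of what the source reports. "The series", "measured", "known", "first", "only" and "open" are said of these compounds alone.

compound 1 `COc1ccc2c(/C=C(\C#N)C(=O)c3c[nH]c4cc(F)ccc34)c[nH]c2c1` gives > 50000 nM (a limit)
compound 2 `COc1ccc2[nH]cc(/C=C(\C#N)C(=O)c3c[nH]c4ccccc34)c2c1` gives 25100 nM
compound 3 `N#C/C(=C\c1c[nH]c2cc(F)ccc12)C(=O)c1c[nH]c2cc(F)ccc12` gives > 50000 nM (a limit)

In a functional assay on MIA PaCa-2 cells (Homo sapiens) for cytotoxicity, read by WST assay, with a stated time of 48 h (a higher number here means a weaker inhibitor, a lower number a stronger inhibitor), compound 3 gives > 50000 nM (a limit of the assay and not a number). Compound 1 gives > 50000 nM (also a limit). Most of the data therefore rest on the limit of > 50000 nM in this assay, at which 2 of the 3 values shown sit, and only compound 2 gives a true number.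

Compound 4 `N#C/C(=C\c1c[nH]c2cc(F)ccc12)C(=O)c1c[nH]c2ccccc12` differs from compound 3 by a single change, hydrogen in place of fluoro on an aromatic carbon. Among the measured compounds shown here, the one measured step between neighbours is a step that the two limits leave unreadable from compound 1 to compound 3 and it offers no size to carry over. Compound 2 also has hydrogen in that place, but it differs from compound 4 elsewhere as well. Since compound 2 gives 25100 nM in this assay a modest gain in strength is expected. Another limit is still quite possible for compound 4. The estimated size is an at least 1.5-fold lower number from compound 3 to compound 4 (0.19 log units; that floor lies within the scatter) (towards a stronger inhibitor). Compound 4 is expected at about 32000 nM (estimated range 12000 nM to 60000 nM).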

Compound 4, half-maximal inhibitory concentration: 31600 nM
Beside the measured number, compound 4's estimate is 1.0-fold (0.01 log units) above it, and the stated range covers the measured number.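

Hydrogen in place of fluoro at this place gives the first step in the series that can be read, an at least 1.5-fold lower number from compound 3 to compound 4 (0.19 log units; that floor lies within the scatter), in this assay, whereas the earlier step, with limits at both ends, cannot be read. Compound 3 gives > 50000 nM, which is a limit of the assay and not a number. The step is therefore only a floor, and the true change may be larger, because one of its ends rests on a limit: the limit of > 50000 nM in this assay, at which 2 of the 4 values shown sit.

The compounds shown leave open how a chloro group or an amine on this same aromatic carbon would read in this assay. They also leave open what hydrogen in place of the remaining fluoro of compound 4 would do, with the rest of the structure unchanged.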